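Capping the phenol: methoxy in place of hydroxy

A few compounds are considered here, and "the series" means these few. Any claim that something is new, unique, unknown or untested is made for them only; others in the source may bear on it.

Measured compounds:
- compound 1, `COc1ccc2c(=O)c(/C=C/C(=O)Nc3cccc(Cl)c3)coc2c1`, gives 11900 nM
- compound 2, `Cc1ccccc1NC(=O)/C=C/c1coc2cc(O)ccc2c1=O`, gives 8670 nM
- compound 3, `O=C(/C=C/c1coc2cc(O)ccc2c1=O)NCc1ccccc1`, gives only a limit, > 100000 nM

These values come from a functional assay on HeLa cells (Homo sapiens) for inhibition, read by MTT assay, with a stated time of 48 h; on this read-out higher numbers stand for weaker inhibition and lower numbers for stronger inhibition. All three compounds share one core and differ in what sits on the amide-type nitrogen and on the ring oxygen. Compound 2 stands lowest of the two numbers given; compound 1 is nearest, and the gap between them lies within the usual scatter, so no order between them can be claimed. Compound 3 gives a limit in this assay rather than a number. Going by the values given here, the one step measured at a single place, an at least 11-fold higher number from compound 2 to compound 3 (1.06 log units; beyond the scatter), is large; it can be given only as a lower bound because compound 3 sits at the limit of > 100000 nM in this assay, at which 1 of the 3 values shown sits.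

Compound 4, `COc1ccc2c(=O)c(/C=C/C(=O)Nc3ccccc3C)coc2c1`, differs from compound 2 by methyl in place of hydrogen on an oxygen on an aromatic ring. Among the compounds with values here, no measured pair differs only in this place. Compound 1 carries the same methoxy group but also another ring on the amide-type nitrogen, so all that can be said is that its value and that of compound 2 lie within the scatter of each other. Within the data shown here, with no measured step bearing on this change, the expected step is a 1.0-fold higher number from compound 2 to compound 4 (0.02 log units; within the scatter), which is not beyond the scatter. Compound 4 is therefore estimated at 9000 nM, in a range from 3000 nM to 30000 nM.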

Compound 4, half-maximal inhibitory concentration: 7270 nM
Compound 4: the middle estimate sits 1.2-fold (0.09 log units) above what was measured; measured number inside the range.
By their numbers in this assay, from the lowest: compounds 4, 2 and 1 (each within the scatter of the next). At a limit, above all of these: compound 3.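

In this assay the phenol can now be read directly: with 2-methylphenyl held fixed on the amide-type nitrogen, methoxy in place of hydroxy gives a 1.2-fold lower number from compound 2 to compound 4 (0.08 log units; within the scatter) and so shows no measurable change, meaning that in this pair the hydrogen on that oxygen makes no visible difference to the read-out. With the methoxy group held fixed, 2-methylphenyl in place of 3-chlorophenyl on the amide-type nitrogen gives a 1.6-fold lower number from compound 1 to compound 4 (0.21 log units; within the scatter) and so leaves these two rings indistinguishable in this assay. Compound 1 and compound 2 differ in two places and could not offer this comparison. The data shown give no explanation for why either change leaves the number within the scatter.

Compound 3 gives > 100000 nM, which is a limit of the assay and not a number. On these data alone, it remains open whether methoxy would also leave the read-out unchanged with benzyl on the amide-type nitrogen, and whether an ethyl group or a longer chain on that oxygen, or an amine in its place, would do the same.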